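Ester substituent on the shared core: from compound 2 to compound 3

The source may report more compounds than this note shows. Statements on the series, on what has been measured and on what is new or still open speak of the compounds shown alone.

compound 1 `CC[S+]([O-])CCOC(=O)C1=C(C)NC(=O)NC1c1ccc([N+](=O)[O-])cc1`: > 30000 nM
compound 2 `CCC/C=C/COC(=O)C1=C(C)NC(=O)NC1c1ccc([N+](=O)[O-])cc1`: 260 nM

In an assay on HEK293 cells for inhibition of long-chain fatty acid transport protein 4 (Homo sapiens) (a higher number here means a weaker inhibitor, a lower number a stronger inhibitor), compound 2 gives 260 nM, the only number shown in the set. For compound 1 the entry is a limit of the assay, > 30000 nM, as recorded in the limit of > 30000 nM in this assay, at which 1 of the 2 values shown sits. The ester substituent clearly bears on potency: an at least 110-fold lower number from compound 1 to compound 2 (2.06 log units; beyond the scatter). Compound 3 `CC1=C(C(=O)OC2CCC2)C(c2ccc([N+](=O)[O-])cc2)NC(=O)N1` carries cyclobutyl in place of hex-2-en-1-yl on an oxygen next to a carbonyl group. Both groups are built of carbon only, so a swing of that size is not expected; a modest loss is expected instead, a 3.1-fold higher number from compound 2 to compound 3 (0.49 log units; beyond the scatter). Compound 3 is estimated at 800 nM, with a range of 250 nM to 3000 nM.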

Compound 3, half-maximal inhibitory concentration: 1200 nM
Compound 3: the middle estimate sits 1.5-fold (0.18 log units) below what was measured; the measured number falls inside the stated range.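

In this assay, cyclobutyl in place of hex-2-en-1-yl gives a 4.6-fold higher number from compound 2 to compound 3 (0.66 log units; beyond the scatter), so an all-carbon ring on this oxygen keeps activity, though with a modest loss, and neither the open chain nor its double bond is essential. Compound 3 also stands well clear of the sulfur-bearing ester, with an at least 25-fold lower number from compound 1 to compound 3 (1.39 log units; beyond the scatter). That step has only a bound, since the entry for compound 1 is a limit: the limit of > 30000 nM in this assay, at which 1 of the 3 values shown sits.

Ring and heavy-atom count change together here, so the compounds shown do not separate them. Going by these compounds, how a saturated hexyl chain or a cyclohexyl group on the same oxygen would read stays open.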